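A Triazole in Place of Pyrrole: Expected Paw-Edema Dose

The compounds below may be only part of what the source reports. "The series", "measured", "known", "first", "only" and "open" are said of these compounds alone.

Compound 1 `O=C(O)c1cc(-n2cccc2)ccc1O`: 50 mg/kg
Compound 2 `O=C(O)c1cc(-c2ccns2)ccc1O`: 80 mg/kg
Compound 3 `O=C(O)c1cc(-c2cscn2)ccc1O`: 95 mg/kg

Of the compounds shown here, three sharing one core have been tested in a functional assay on the whole organism for inhibition, with Rattus norvegicus as the target, read by paw edema; on this read-out lower numbers stand for an effect already at smaller amounts and higher numbers for an effect only at larger amounts of compound. Compound 1 has the lowest of the three numbers; its nearest neighbour is compound 2, reached by a 1.6-fold higher number from compound 1 to compound 2 (0.20 log units; within the scatter), and the furthest is compound 3, reached by a 1.9-fold higher number from compound 1 to compound 3 (0.28 log units; within the scatter). Both steps lie within the scatter, so none of the three can be called more or less potent than another. Between the two sulfur-containing analogues the step is a 1.2-fold higher number from compound 2 to compound 3 (0.07 log units; within the scatter), again within the scatter.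

Compound 4 `O=C(O)c1cc(-n2ccnn2)ccc1O` has not yet been measured. It differs from compound 1 in one place: 1H-1,2,3-triazol-1-yl in place of 1H-pyrrol-1-yl on an aromatic carbon The steps from compound 1 to compound 2 and from compound 1 to compound 3 bear on this change: each of them also replaces 1H-pyrrol-1-yl with a different five-membered aromatic ring on the same aromatic carbon, and neither moved the number beyond the scatter. With only these two comparisons available, a similar outcome is expected. Compound 4 is therefore expected to give 70 mg/kg, with a range from 35 mg/kg to 140 mg/kg, meaning a step of a 1.4-fold higher number from compound 1 to compound 4 (0.15 log units; within the scatter) that is expected to stay within the scatter.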

Compound 4, dose for half-maximal effect: 150 mg/kg
For compound 4 the middle estimate is 2.1-fold (0.33 log units) below the measured one; the whole stated range lies below it.
By their numbers in this assay, from the lowest: compounds 1, 2, 3 and 4 (each within the scatter of the next, the first and the last beyond it).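

In this assay, for the compounds shown here, 1H-1,2,3-triazol-1-yl in place of 1H-pyrrol-1-yl, on the aromatic carbon meta to the carboxy group and para to the hydroxy group, gives the only step at this position that leaves the scatter: a 3.0-fold higher number from compound 1 to compound 4 (0.48 log units; beyond the scatter), a modest change. The triazole is still not set apart from the two thiazole rings, as a 1.6-fold higher number from compound 3 to compound 4 (0.20 log units; within the scatter) and a 1.9-fold higher number from compound 2 to compound 4 (0.27 log units; within the scatter) both stay within the scatter, so this position shows a real difference only between the two ends of the series, compound 1 and compound 4. The entering ring carries 3 hetero atoms against 1 in the pyrrole ring, but nothing measured here connects that count to the step or explains the result.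

From the compounds shown here alone, all four compounds carry a five-membered aromatic ring at this place, so what a phenyl ring, an amine or a short alkyl chain would do there stays open. An imidazole ring or a 1,2,4-triazole ring would help to show whether the step follows the number of ring nitrogens or the particular arrangement found in compound 4.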